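Methyl ester to methyl amide and cell toxicity

The source may hold more compounds than are shown below. What is called first, only, known or untested is meant among the compounds shown, and "the series" means these compounds.

The study compares two measured compounds and one that still awaits testing. Compound 1 `COC(=O)c1cc(N)c(Nc2ccc(C#N)cc2)cc1Oc1c(C)cc(/C=C/C#N)cc1C` and compound 2 `Cc1cc(C#N)cc(C)c1Oc1cc(Nc2ccc(C#N)cc2)c(N)cc1C(F)(F)F` were both run in an ADME assay on TZM cells (Homo sapiens) for cytotoxicity, read by XTT assay, with a stated time of 4 days; on this read-out higher numbers stand for lower toxicity in this test and lower numbers for higher toxicity in this test. For compound 1 only a limit is reported, and it stands at > 22800 nM. Compound 2 gives a number in this assay, 13300 nM. Among the measured compounds shown here, because one of the two values sits at the limit of > 22800 nM in this assay, at which 1 of the 2 values shown sits, there is no measured step here that could tell how a single change moves the read-out; compound 1 and compound 2 differ in several places at once, so only their two values can be set side by side.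

Compound 3 `CNC(=O)c1cc(N)c(Nc2ccc(C#N)cc2)cc1Oc1c(C)cc(/C=C/C#N)cc1C` is the untested one. It differs from compound 1 by methylamino in place of methoxy on a carbonyl carbon. For the measured compounds named here, with no step between measured compounds to lean on, the account can only say that the change is small in size and that, on this read-out, any shift from compound 1 to compound 3 is expected to stay within the scatter, with a step that the limit leaves unreadable from compound 1 to compound 3 as the estimated step. Compound 3 is therefore expected at 25000 nM, between 10000 nM and 60000 nM, most likely again reported only as a limit.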

Compound 3, half-maximal cytotoxic concentration: > 9200 nM
Compound 3: only a limit was reported; the forecaster's own chance of this, stated with the estimate: 60%; the middle value lies beyond the limit too.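

In this assay, among the compounds shown here, compound 1 and compound 3 are each reported only as a limit, and no step between them can be read. The compounds shown leave open whether methylamino in place of methoxy on a carbonyl carbon moves the half-maximal cytotoxic concentration at all, and in which direction.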